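The source may report more compounds than this note shows. Statements on the series, on what has been measured and on what is new or still open speak of the compounds shown alone.

Measured so far:
compound 1, `Clc1cccc(CSc2nnc(-c3ccncc3)n2-c2ccccc2)c1`, 10500 nM
compound 2, `O=C(CSc1nnc(-c2ccncc2)n1-c1ccccc1)N/N=C/c1ccc(F)cc1`, 12300 nM

Both numbers come from a functional assay on MCF7 cells (Homo sapiens) for inhibition, read by MTT assay, with a stated time of 48 h; on this read-out higher numbers stand for weaker inhibition and lower numbers for stronger inhibition. On this read-out compound 2 gives 12300 nM, and the only companion, compound 1, gives 10500 nM; the two values lie within the usual scatter of each other, so no order can be read between them.

Compound 3, `O=C(CSc1nnc(-c2ccncc2)n1-c1ccccc1)N/N=C/c1ccc(O)c(O)c1`, has not yet been measured. It differs from compound 2 in one place: 3,4-dihydroxyphenyl in place of 4-fluorophenyl on a carbon with a double bond to nitrogen. The rest of the molecule, including the shared core and the hydrazone linker, is unchanged.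

Among the measured compounds shown here, no pair of measured compounds shows the effect of such an exchange, so nothing in the data points to a direction. Compound 3 is therefore expected to remain close to compound 2, with a step of a 1.4-fold lower number from compound 2 to compound 3 (0.14 log units; within the scatter) that is not expected to exceed the scatter. The estimate for compound 3 in this assay is 9000 nM, with a plausible range from 3000 nM to 30000 nM.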

Compound 3, half-maximal inhibitory concentration: 19700 nM
Beside the measured number, compound 3's estimate is 2.2-fold (0.34 log units) below it; the measured number falls inside the stated range.
By their numbers in this assay, from the lowest: compounds 1, 2 and 3 (each within the scatter of the next).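

In this assay, among the compounds shown here, the exchange of 4-fluorophenyl for 3,4-dihydroxyphenyl on a carbon with a double bond to nitrogen gives a 1.6-fold higher number from compound 2 to compound 3 (0.20 log units; within the scatter) and so provides the first step at this position that can be read. The entering group carries 2 hydrogen-bond donors and 2 hydrogen-bond acceptors against 0 of each in the group that leaves, yet this read-out does not separate compound 2 from compound 3. No separate measurement is available to explain this outcome.

The compounds shown leave open whether an aromatic ring bearing an amine or a carboxylic acid at this place would also stay within the scatter of compound 2. They also leave open whether a simple alkyl chain in place of the aromatic ring would do so.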